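Swapping the acyl group for a benzyl ester tether

The source may hold more compounds than are shown below. What is called first, only, known or untested is meant among the compounds shown, and "the series" means these compounds.

Among the measured compounds shown here, compound 2 `COC(=O)CC(=O)NC1=CS(=O)(=O)O[C@@]12[C@@H](CO[Si](C)(C)C(C)(C)C)O[C@@H](n1cc(C)c(=O)n(C)c1=O)[C@@H]2O[Si](C)(C)C(C)(C)C` is the only compound of this set with a numerical read-out. In a functional assay on HEL cells (Homo sapiens) for cytotoxicity, read by microscopy (a higher number here means that more compound is tolerated, a lower number that less compound is tolerated), compound 2 gives 400000 nM. Compound 1 `COC(=O)NC1=CS(=O)(=O)O[C@@]12[C@@H](CO[Si](C)(C)C(C)(C)C)O[C@@H](n1cc(C)c(=O)n(C)c1=O)[C@@H]2O[Si](C)(C)C(C)(C)C` is reported in this assay only as a limit, >= 50000 nM. The step that the limit leaves unreadable from compound 1 to compound 2 cannot be sized because of the limit of >= 50000 nM in this assay, at which 1 of the 2 values shown sits. For the measured compounds named here, compound 2 therefore stands alone as the single number, with nothing measured around it to show which direction a change in the substituent on the amine nitrogen tends to take.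

Compound 3 `Cc1cn([C@@H]2O[C@H](CO[Si](C)(C)C(C)(C)C)[C@@]3(OS(=O)(=O)C=C3NCCC(=O)OCc3ccccc3)[C@H]2O[Si](C)(C)C(C)(C)C)c(=O)n(C)c1=O` differs from compound 2 in one place: 2-(benzyloxycarbonyl)ethyl in place of ((methoxycarbonyl)methyl)carbonyl on an amine nitrogen. The acyl group of compound 2 gives way to an alkyl chain ending in a benzyl ester, so the nitrogen loses its carbonyl neighbour and the substituent grows by a benzene ring.

Going by the values given here, no measured step bears on this change, so the expectation rests on compound 2 alone. A step of moderate size toward a lower tolerated concentration is expected, a 4.0-fold lower number from compound 2 to compound 3 (0.60 log units; beyond the scatter), though a limit read-out remains quite possible. Compound 3 is estimated at 100000 nM, with a range from 20000 nM to 400000 nM.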

Compound 3, minimum cytotoxic concentration: >= 400000 nM
Compound 3 was reported as a limit; the forecaster's own chance of this, stated with the estimate: 40%; at least 4.0-fold (0.60 log units) between middle value and limit.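

Replacing ((methoxycarbonyl)methyl)carbonyl with 2-(benzyloxycarbonyl)ethyl on the amine nitrogen gives a number no lower from compound 2 to compound 3 (the limit leaves the size open) in this assay. Among the compounds shown here, this is the first direction that can be read at this position: the nitrogen loses its acyl carbonyl and carries a chain ending in a benzyl ester, with no measured fall in the tolerated concentration. The reading of compound 3 is a limit and not a number: the limit of >= 400000 nM in this assay, at which 1 of the 3 values shown sits.

From the compounds shown here alone, the steps that start from compound 1 cannot be read, and the distance between compound 2 and compound 3 stays open. The compounds shown also do not separate the loss of the carbonyl from the gain of the benzene ring, and they leave open how a free carboxylic acid or an amine at the end of the chain would read in this assay.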